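The compounds below may be only part of what the source reports. "The series", "measured", "known", "first", "only" and "open" are said of these compounds alone.

In a functional assay on HeLa cells (Homo sapiens) for antiproliferative activity, read by MTT assay, with a stated time of 72 h (a higher number here means a weaker inhibitor, a lower number a stronger inhibitor), compound 1 (`Nc1nc(N)c2cc(CSC(=S)N3CCN(c4ccccc4)CC3)ccc2n1`) gives 2840 nM, compound 2 (`Cc1ccc(N2CCN(C(=S)SCc3ccc4nc(N)nc(N)c4c3)CC2)c(C)c1`) gives 3190 nM and compound 3 (`Nc1nc(N)c2cc(CSC(=S)N3CCN(c4ccc(Cl)cc4)CC3)ccc2n1`) gives 6990 nM, the highest number and so the weakest inhibitor of the three. Compound 4 (`Nc1nc(N)c2cc(CSC(=S)N3CCN(c4ccc(F)cc4F)CC3)ccc2n1`) has 2,4-difluorophenyl in place of 4-chlorophenyl on an amine nitrogen in a ring. Among the measured compounds shown here, three measured steps bear on this. Chloro in place of hydrogen gave a 2.5-fold higher number from compound 1 to compound 3 (0.39 log units; beyond the scatter), and 4-chlorophenyl in place of 2,4-dimethylphenyl gave a 2.2-fold higher number from compound 2 to compound 3 (0.34 log units; beyond the scatter), both modest. By contrast, 2,4-dimethylphenyl in place of phenyl gave a 1.1-fold higher number from compound 1 to compound 2 (0.05 log units; within the scatter), within the scatter. For the measured compounds named here, no measured compound carries fluoro, so the expectation is loose: a modest move to a lower number in this assay, an expected 1.7-fold lower number from compound 3 to compound 4 (0.24 log units; within the scatter). Compound 4 is estimated at 4000 nM, with a range of 2000 nM to 8000 nM.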

Compound 4, half-maximal inhibitory concentration: 3800 nM
Compound 4: middle estimate off by 1.1-fold (0.02 log units), on the high side; the measured number falls inside the stated range.
By their numbers in this assay, from the lowest: compounds 1, 2, 4 and 3 (each within the scatter of the next, the first and the last beyond it).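

In this assay, 2,4-difluorophenyl on the amine nitrogen gives a 1.8-fold lower number from compound 3 to compound 4 (0.26 log units; within the scatter), a 1.2-fold higher number from compound 2 to compound 4 (0.08 log units; within the scatter) and a 1.3-fold higher number from compound 1 to compound 4 (0.13 log units; within the scatter). Fluoro, new at this position, therefore cannot be told apart from phenyl, 2,4-dimethylphenyl or 4-chlorophenyl here, although compound 3 remains separated from compound 1 and compound 2 by more than the scatter. Nothing measured here explains these results. On these data alone, how 4-fluorophenyl would compare remains open, as does the effect of a phenyl ring carrying an amine or a carboxylic acid.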